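Series notes: removing the cyclopentyl from compound 1

This account rests on a few compounds, and the source may have more. Where it says the series, first, only, none or still open, it means among the compounds named here.

Among the measured compounds shown here, compound 1 `COc1cc(-c2cnn3cc(OC)c(C4CCCC4)nc23)ccn1` is the weakest of the three measured members in an ADME assay on microsomes from liver (Rattus norvegicus) for metabolic stability, with a stated time of 60 min, tested at 1 uM (a higher number here means that more of the compound is left, a lower number that less of the compound is left), where compound 1 gives 7%. Compound 2 `COc1cn2ncc(-c3ccnc(OC(C)C)c3)c2nc1-c1cnn(C)c1` gives 50% and compound 3 `COc1cc(-c2cnn3cc(OC)c(-c4cnn(C)c4)nc23)ccn1` gives 56%; the gap between them, a number 6 percentage points higher from compound 2 to compound 3 (within the scatter), is within the scatter. Compound 4 `COc1cnc2c(-c3ccnc(OC)c3)cnn2c1` differs from compound 1 by hydrogen in place of cyclopentyl on an aromatic carbon. For the measured compounds named here, the only measured step at this position is a number 49 percentage points higher from compound 1 to compound 3 (beyond the scatter), a large gain once the cyclopentyl is gone; no measured pair shows the cyclopentyl replaced by hydrogen itself, so the size is uncertain. A gain beyond the scatter is expected, though likely smaller than with compound 3, giving an estimated a number 33 percentage points higher from compound 1 to compound 4 (beyond the scatter). Compound 4 is estimated at 40%, within 15% to 70%.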

Compound 4, percent of the compound remaining: 10%
Compound 4: the middle estimate sits 30 percentage points above what was measured; the measured number lies below the stated range.
By their numbers in this assay, from the lowest: compounds 1 and 4 (each within the scatter of the next); then compounds 2 and 3 (each within the scatter of the next).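

Losing the cyclopentyl does not by itself raise the number in this assay (see a number 3 percentage points higher from compound 1 to compound 4 (within the scatter)). The gain seen with compound 3 therefore goes with the 1-methyl-1H-pyrazol-4-yl itself, as hydrogen in its place gives a large drop (a number 46 percentage points lower from compound 3 to compound 4 (beyond the scatter)). No measured evidence accounts for this difference between the groups.

Open, from the compounds shown here alone, is whether an amine, a phenyl or a plain pyrazole on this aromatic carbon would stand with compound 3 or with compound 4. Also open, going by these compounds, is whether the methyl on the pyrazole contributes to the number.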